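Swapping Nitro for Cyano Across Two Related Cores

This account rests on a few compounds, and the source may have more. Where it says the series, first, only, none or still open, it means among the compounds named here.

Compound 1 `CC(CS(=O)(=O)c1ccc(C(F)(F)F)cc1)C(=O)Nc1ccc(C#N)cc1C(F)(F)F` and compound 3 `CC(CS(=O)(=O)c1ccc(C(F)(F)F)cc1)C(=O)Nc1ccc([N+](=O)[O-])cc1C(F)(F)F` share one core, while compound 2 `CC(CS(=O)(=O)c1cc(C(F)(F)F)cc(C(F)(F)F)c1)C(=O)Nc1ccc(C#N)cc1C(F)(F)F` is built on a second core; the difference between the two cores is not broken down here. In a functional assay on LNCaP cells (Homo sapiens) for antiproliferative activity, read by MTT assay, with a stated time of 96 h (on this read-out lower numbers stand for stronger inhibition and higher numbers for weaker inhibition), compound 1 gives 28800 nM, compound 3 gives 26300 nM, and compound 2 gives 9560 nM, the lowest number of the three. The change from compound 1 to compound 3 is nitro in place of cyano on an aromatic carbon, and it made a 1.1-fold lower number from compound 1 to compound 3 (0.04 log units; within the scatter). Compound 4 `CC(CS(=O)(=O)c1cc(C(F)(F)F)cc(C(F)(F)F)c1)C(=O)Nc1ccc([N+](=O)[O-])cc1C(F)(F)F` has not yet been measured in this assay. It arises from compound 2 by the same change, (nitro in place of cyano on an aromatic carbon), at a place described in the same words. Because a 1.1-fold lower number from compound 1 to compound 3 (0.04 log units; within the scatter) was small, the expected step of a 1.1-fold lower number from compound 2 to compound 4 (0.04 log units; within the scatter) is small as well. Compound 4 is therefore estimated at 8700 nM, with a range from 4500 nM to 18000 nM.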

Compound 4, half-maximal inhibitory concentration: 3080 nM
Estimate against measurement, compound 4: 2.8-fold (0.45 log units) above; the measured number lies below the stated range.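

In this assay, nitro in place of cyano made a 3.1-fold lower number from compound 2 to compound 4 (0.49 log units; beyond the scatter), so the size of this change did not carry over unchanged from one core to the other: the same change on two cores in this assay, a 1.1-fold lower number (0.04 log units; within the scatter) from compound 1 to compound 3 and a 3.1-fold lower number (0.49 log units; beyond the scatter) from compound 2 to compound 4, 2.8-fold (0.45 log units) apart, beyond the scatter of two such steps. In this series, then, the step measured on one core cannot simply be copied onto the other, since the same swap made little difference on the core of compound 1 but a clear one on the core of compound 2. These two pairs do not show why the cores behave differently, nor how the change would act on any further core.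

On these data alone, it remains open whether an amine or a carboxylic acid in place of the cyano would also give steps that differ between these cores. As far as these compounds go, it is equally open which part of the core sets the size of the step.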